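The source may hold more compounds than are shown below. What is called first, only, known or untested is meant among the compounds shown, and "the series" means these compounds.

Among the compounds with values here, in a functional assay on A-375 cells (Homo sapiens) for activation, with a stated time of 3 days (on this read-out higher numbers stand for an effect only at larger amounts of compound and lower numbers for an effect already at smaller amounts), compound 2 (`O=C(Nc1ccc(-c2cccnc2)cc1)C1CCCN(Cc2ccc(F)c(F)c2)C1`) gives 1060 nM, the lowest of the two numbers so far, while compound 1 (`O=C(Nc1ccc(-c2ccccc2)cc1)C1CCCN(Cc2ccc(F)c(F)c2)C1`) gives 5000 nM. Compound 3 (`O=C(Nc1ccc(-c2ccccn2)cc1)C1CCCN(Cc2ccc(F)c(F)c2)C1`) has pyridin-2-yl in place of pyridin-3-yl on an aromatic carbon. Within the data shown here, the one measured step that bears on this change is a 4.7-fold lower number from compound 1 to compound 2 (0.67 log units; beyond the scatter). That modest step replaced phenyl, whereas here the atoms stay the same, so a smaller change is expected, with a slight rise at most. The expected change is a 1.4-fold higher number from compound 2 to compound 3 (0.15 log units; within the scatter), which would lie within the scatter. Compound 3 is estimated at 1500 nM, with an expected range from 500 nM to 4500 nM.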

Compound 3, half-maximal effective concentration: 11000 nM
Beside the measured number, compound 3's estimate is 7.3-fold (0.87 log units) below it; measured number above the stated range.
By their numbers in this assay, from the lowest: compound 2; then compound 1; then compound 3.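

In this assay, the same atoms joined differently give a 10-fold higher number from compound 2 to compound 3 (1.02 log units; beyond the scatter), so at this place, para to a large group, the site of the ring nitrogen matters and not merely its presence. Pyridin-2-yl also gives a 2.2-fold higher number from compound 1 to compound 3 (0.34 log units; beyond the scatter), the opposite direction to a 4.7-fold lower number from compound 1 to compound 2 (0.67 log units; beyond the scatter), so a pyridine in place of phenyl does not lower the number in every form. No measurement shown accounts for this difference between the two pyridines. The compounds shown leave open how pyridin-4-yl would read at this place, and whether an amine on the pyridin-3-yl ring would lower the number further.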